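A few compounds are considered here, and "the series" means these few. Any claim that something is new, unique, unknown or untested is made for them only; others in the source may bear on it.

Compound 1 `Nc1sc(-c2ccc(Cl)cc2)c(-c2ccc(Cl)cc2)c1C(=O)N1CCNCC1`: 2710 nM
Compound 2 `Nc1sc(-c2ccc(Cl)cc2)c(-c2ccc(Cl)cc2)c1C(=O)N1CCC(=O)CC1=O`: 9230 nM
Compound 3 `Nc1sc(-c2ccc(Cl)cc2)c(-c2ccc(Cl)cc2)c1C(=O)N1CCCCC1=O`: 4940 nM

All three share one core and differ only in the group on the carbonyl carbon. In a functional assay on PC-3 cells (Homo sapiens) for inhibition, read by sulforhodamine B assay, with a stated time of 72 h (on this read-out lower numbers stand for stronger inhibition and higher numbers for weaker inhibition), compound 3 has the second highest number of the three; the step of a 1.8-fold higher number from compound 1 to compound 3 (0.26 log units; within the scatter) and the step of a 1.9-fold lower number from compound 2 to compound 3 (0.27 log units; within the scatter) both lie within the scatter, so no order among these can be claimed. Compound 4 `Nc1sc(-c2ccc(Cl)cc2)c(-c2ccc(Cl)cc2)c1C(=O)Nc1ccccc1` carries a change at the same place: anilino in place of 2-oxopiperidin-1-yl on a carbonyl carbon. Every measured step swaps this group, and the largest, a 3.4-fold higher number from compound 1 to compound 2 (0.53 log units; beyond the scatter), was only modest; none involved an aromatic amine, so the expectation rests on that small spread. The step of a 1.1-fold lower number from compound 3 to compound 4 (0.04 log units; within the scatter) is expected to stay near the scatter. Compound 4 is estimated at 4500 nM, between 1500 nM and 14000 nM.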

Compound 4, half-maximal inhibitory concentration: > 50000 nM
Compound 4 was reported as a limit (the forecaster's own chance of this, stated with the estimate: 5%); middle value at least 11-fold (1.04 log units) away from the limit.
By their numbers in this assay, from the lowest: compounds 1, 3 and 2 (each within the scatter of the next, the first and the last beyond it). At a limit, above all of these: compound 4.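

In this assay compound 4 gives > 50000 nM as a limit, not a number. Anilino in place of the non-aromatic rings gives an at least 10-fold higher number from compound 3 to compound 4 (1.00 log units; beyond the scatter) and an at least 5.4-fold higher number from compound 2 to compound 4 (0.73 log units; beyond the scatter) and an at least 18-fold higher number from compound 1 to compound 4 (1.26 log units; beyond the scatter) as well, all beyond the scatter. So the group on this carbonyl carbon, where swaps among non-aromatic rings moved the number only modestly, can matter much more, even though anilino has the same count of heavy atoms as 2-oxopiperidin-1-yl.

Anilino brings an aromatic ring and a hydrogen-bond donor together, so it stays open which of the two goes with the loss. Cyclohexylamino, which keeps the amide hydrogen without the aromatic ring, and N-methylanilino, which keeps the ring without that hydrogen, would separate them.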